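Changing the Carbonyl Group on Compound 2

The source may report more compounds than this note shows. Statements on the series, on what has been measured and on what is new or still open speak of the compounds shown alone.

In a functional assay on Caco-2 cells (Homo sapiens), read by MTT assay, with a stated time of 48 h (a lower number here means a stronger inhibitor, a higher number a weaker inhibitor), compound 1 `CCN(CC)CCCNC(=O)c1ccc(C(CC)(CC)c2ccc(OCC(O)C(C)(C)C)c(C)c2)n1CC` gives 1800 nM and compound 2 `CCn1c(C(=O)N(CCC#N)CCC#N)ccc1C(CC)(CC)c1ccc(OCC(O)C(C)(C)C)c(C)c1` gives 7100 nM, so compound 2 holds the higher of the two numbers and is the weaker inhibitor. Compound 3 `CCn1c(C(=O)OCc2ccc(F)cc2)ccc1C(CC)(CC)c1ccc(OCC(O)C(C)(C)C)c(C)c1` keeps the shared core and differs from compound 2 only in the group on the carbonyl carbon, where (4-fluorobenzyl)oxy enters: a group of 9 heavy atoms (7 carbon, 1 oxygen, 1 fluorine; one six-membered aromatic ring of carbon only) in place of a group of 9 heavy atoms (6 carbon, 3 nitrogen; no ring), on a carbonyl carbon. Among the compounds with values here, one measured step bears on this place, a 3.9-fold higher number from compound 1 to compound 2 (0.60 log units; beyond the scatter), and it shows that changing this group can move the number beyond the scatter. A single step cannot fix the direction for a new group that carries a ring. Since compound 2 already stands highest, a somewhat smaller step toward a lower number is expected in this assay, and the expected change is a 2.4-fold lower number from compound 2 to compound 3 (0.37 log units; beyond the scatter). The estimate for compound 3 is 3000 nM, within an expected range of 900 nM to 10000 nM.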

Compound 3, half-maximal inhibitory concentration: > 50000 nM
Compound 3: a limit, no number (the forecaster's own chance of this, stated with the estimate: 10%); middle value at least 16-fold (1.22 log units) from the limit.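

In this assay compound 3 gives only a limit of the assay, not a number: the limit of > 50000 nM in this assay, at which 1 of the 3 values shown sits. From the compounds shown here alone, the change of group therefore has a minimum size, an at least 7.0-fold higher number from compound 2 to compound 3 (0.84 log units; beyond the scatter) and an at least 27-fold higher number from compound 1 to compound 3 (1.44 log units; beyond the scatter), and both steps show that compound 3 is the weakest of the three inhibitors, though its true value is unknown. The leaving and entering groups in the step from compound 2 have the same heavy-atom count, so a matching count at this carbonyl carbon does not keep the number in place, and the earlier step between two nitrogen-bearing groups could not show this.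

The aromatic ring, the fluorine and the oxygen enter together, so these compounds cannot separate their contributions. A benzylamino group or a carboxylic acid on this carbonyl carbon remains an open comparison.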